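A few compounds are considered here, and "the series" means these few. Any claim that something is new, unique, unknown or untested is made for them only; others in the source may bear on it.

In a functional assay on HCT-15 cells (Homo sapiens) for cytotoxicity, read by ELISA, with a stated time of 2 days (a higher number here means a weaker inhibitor, a lower number a stronger inhibitor), the measured compounds give these values
compound 1 `Oc1cccc(-c2cc(-c3ccccc3)nc(-c3cccs3)c2)c1` gives 14100 nM
compound 2 `Oc1cccc(-c2cc(-c3ccccc3)nc(-c3ccsc3)c2)c1` gives 24600 nM
compound 3 `Oc1cccc(-c2cc(-c3ccccc3)nc(-c3ccco3)c2)c1` gives 13900 nM

Compound 3 (13900 nM) cannot be told apart from the other two compounds. The gaps are (a 1.0-fold lower number from compound 1 to compound 3 (0.01 log units; within the scatter)) and (a 1.8-fold lower number from compound 2 to compound 3 (0.25 log units; within the scatter)), so both lie within the ordinary noise of such measurements.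

The next compound, compound 4 `Oc1cccc(-c2cc(-c3ccccc3)nc(-c3ccccn3)c2)c1` carries pyridin-2-yl in place of furan-2-yl, on an aromatic carbon next to the ring nitrogen (pyridin-2-yl in place of furan-2-yl on an aromatic carbon).

Three measured swaps at this same place bear on the question. Those two gaps are joined by the swap of thiophen-2-yl for thiophen-3-yl (a 1.7-fold higher number from compound 1 to compound 2 (0.24 log units; within the scatter)). None of the three rises above the noise, so among compounds 1, 2 and 3 the choice of group here has shown no measurable effect. All three groups, however, are five-membered rings. Among the compounds with values here, no measured compound has a six-membered ring at this place, so the new change is untested and the range must stay wide.

In this assay no step beyond the scatter is expected, in either direction. The expected size of the change is small (a 1.1-fold higher number from compound 3 to compound 4 (0.03 log units; within the scatter)). For compound 4 the estimated value is 15000 nM with an expected range from 6000 nM to 40000 nM and that is where the measurement should land.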

Compound 4, half-maximal inhibitory concentration: 20900 nM
Compound 4: the middle estimate sits 1.4-fold (0.14 log units) below what was measured; measured number inside the range.
By their numbers in this assay, from the lowest: compounds 3, 1, 4 and 2 (each within the scatter of the next).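

In this assay, within the data shown here, pyridin-2-yl is the first six-membered ring at this place on the shared core, and it cannot be told apart from any of the three five-membered rings (a 1.5-fold higher number from compound 3 to compound 4 (0.18 log units; within the scatter); a 1.5-fold higher number from compound 1 to compound 4 (0.17 log units; within the scatter); a 1.2-fold lower number from compound 2 to compound 4 (0.07 log units; within the scatter)). The earlier compounds shown here showed only that exchanging one five-membered aromatic ring for another had no measurable effect, whereas these steps extend that finding to a change in ring size, with one more heavy atom and a ring nitrogen in place of the oxygen or sulfur. Nothing measured here bears on why the values stay so close.

All four compounds carry an aromatic ring with one hetero atom at this place, so the compounds shown do not reveal what a plain phenyl ring, an amine, a carboxylic acid or a longer alkyl chain would do there. They also leave open whether the 3-hydroxyphenyl and phenyl groups, the same in all four compounds, matter for the values in this assay.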